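A larger group on the nitrogen after two limits

The compounds below may be only part of what the source reports. "The series", "measured", "known", "first", "only" and "open" are said of these compounds alone.

- compound 1 `CC(C)(C)C/N=c1\c(O)c(O)\c1=N/c1ccc(C#N)cc1`: > 30000 nM (a limit)
- compound 2 `CCC(C)(C)/N=c1\c(O)c(O)\c1=N/c1ccc(C#N)cc1`: > 30000 nM (a limit)

Both values come from a functional assay for inhibition, with Rattus norvegicus as the target; on this read-out lower numbers stand for stronger inhibition and higher numbers for weaker inhibition. Compound 2 stands at a limit and not at a number, with > 30000 nM. This is the limit of > 30000 nM in this assay, at which 2 of the 2 values shown sit, so no potency can be read for either compound.

Compound 3 `C[C@@H](/N=c1\c(O)c(O)\c1=N/c1ccc(C#N)cc1)C1CCCCC1` has not yet been measured. It differs from compound 2 as follows: 1-cyclohexylethyl in place of 1,1-dimethylpropyl on a double-bonded nitrogen. The new group, 1-cyclohexylethyl, brings a six-membered non-aromatic ring to the double-bonded nitrogen.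

Among the compounds with values here, only one measured step bears on this, a swap at that same nitrogen: a step that the two limits leave unreadable from compound 1 to compound 2. It gives no size to carry over, so any forecast is loose, and another limit is quite possible. Any shift is expected towards stronger inhibition, and the expected step is an at least 1.5-fold lower number from compound 2 to compound 3 (0.17 log units; that floor lies within the scatter). For compound 3 the estimated value is 20000 nM, with an expected range of 3000 nM to 60000 nM.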

Compound 3, half-maximal inhibitory concentration: 2600 nM
Compound 3: the middle estimate sits 7.7-fold (0.89 log units) above what was measured; measured number below the stated range.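

Putting 1-cyclohexylethyl on the double-bonded nitrogen gives a readable value in this assay and an at least 11-fold lower number from compound 2 to compound 3 (1.06 log units; beyond the scatter). Measured against the neopentyl compound, the same group gives an at least 11-fold lower number from compound 1 to compound 3 (1.06 log units; beyond the scatter). Compound 1 and compound 2 both stand at a limit, so the step between them cannot be read, and the two steps to compound 3 give only a minimum size: the limit of > 30000 nM in this assay, at which 2 of the 3 values shown sit.

The group on compound 3 differs from the other two in its ring, its carbon count and its defined stereocentre all at once, and the compounds shown do not separate these changes. Also open, going by these compounds, is how the opposite stereocentre, a 1-phenylethyl group or a ring carrying an amine would behave at this nitrogen.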